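The source may report more compounds than this note shows. Statements on the series, on what has been measured and on what is new or still open speak of the compounds shown alone.

Working notes on the ester series.

Compound 1 `O=C(NC1CCC(CN2CCN(c3cc(=O)c4cc(C(F)(F)F)cc([N+](=O)[O-])c4s3)CC2)CC1)c1ccccc1` carries a benzamido group on the saturated ring and, in an ADME assay on Vero cells (Chlorocebus sabaeus) for cytotoxicity, read by MTT assay, with a stated time of 48 h (on this read-out lower numbers stand for stronger inhibition and higher numbers for weaker inhibition), compound 1 gives 44.3 ug/mL. Compound 2 `O=C(OC1CCC(CN2CCN(c3cc(=O)c4cc(C(F)(F)F)cc([N+](=O)[O-])c4s3)CC2)CC1)c1cccc(F)c1` has ((3-fluorophenyl)carbonyl)oxy in place of benzamido on a saturated ring carbon. In this assay compound 2 gives only a limit of the assay, > 64 ug/mL, so no number is known for it. The measured step is an at least 1.4-fold higher number from compound 1 to compound 2 (0.15 log units; that floor lies within the scatter); it rests on (the limit of > 64 ug/mL in this assay, at which 1 of the 2 values shown sits), and its size cannot be fixed further because of the limit of > 64 ug/mL in this assay, at which 1 of the 2 values shown sits.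

Compound 3 `O=C(OC1CCC(CN2CCN(c3cc(=O)c4cc(C(F)(F)F)cc([N+](=O)[O-])c4s3)CC2)CC1)c1cccs1` differs from compound 2 only in the ester aryl: thiophen-2-yl in place of 3-fluorophenyl on a carbonyl carbon. Going by the values given here, no measured step covers a change of the aryl on the carbonyl carbon; the only step known, from amide to ester, gave a number that did not leave the usual scatter beyond the floor. The expected change in this assay is therefore a step that the limit leaves unreadable from compound 2 to compound 3, that is, none beyond the scatter, with a fair chance that compound 3 again reaches only a limit. Compound 3 is estimated at 70 ug/mL, within 35 ug/mL to 140 ug/mL.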

Compound 3, half-maximal inhibitory concentration: > 64 ug/mL
Compound 3 gave a limit, no number; the forecaster's own chance of this, stated with the estimate: 55%; the middle value does not contradict the limit.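

In this assay, a five-membered thiophen-2-yl ring on the carbonyl carbon leaves the ester at the limit of the assay, just as the six-membered 3-fluorophenyl ring did, so the limit now holds for two different ester aryl groups rather than one. Measured against the benzamido compound, the change to the thiophen-2-yl ester gives an at least 1.4-fold higher number from compound 1 to compound 3 (0.15 log units; that floor lies within the scatter), which has the same floor as an at least 1.4-fold higher number from compound 1 to compound 2 (0.15 log units; that floor lies within the scatter), so neither ester step is shown to leave the scatter. The step between the two esters cannot be read, and the size of both steps from the amide stays unfixed, because of the following: the limit of > 64 ug/mL in this assay, at which 2 of the 3 values shown sit.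

Still open, on these data alone, is whether an ester aryl carrying an amine or a carboxylic acid would give a number in this assay rather than another limit. Also open is whether the ester aryl matters at all when the link to the saturated ring is the amide, since only the unsubstituted benzamido group is shown there.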